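The source may hold more compounds than are shown below. What is called first, only, known or untested is meant among the compounds shown, and "the series" means these compounds.

Compound 1 `Nc1nc(O)c2c(n1)n(C1OC(CO)[C@@H](O)[C@H]1O)c(=O)n2CC(O)CSc1ccccc1` gives 12% in a functional assay on the whole organism (B cells) with Mus musculus as the target; a lower number here means a smaller maximal response, a higher number a larger maximal response. Compound 2 `CCOC(=O)Cn1c(=O)n(C2OC(CO)[C@@H](O)[C@H]2O)c2nc(N)nc(O)c21` gives 86%. Compound 3 `Nc1nc(O)c2c(n1)n(C1OC(CO)[C@@H](O)[C@H]1O)c(=O)n2Cc1ccccc1` gives 110%.

Compound 3 stands highest of the three, with compound 2 nearest and compound 1 furthest. Compound 4 `[N-]=[N+]=NCC(O)Cn1c(=O)n(C2OC(CO)[C@@H](O)[C@H]2O)c2nc(N)nc(O)c21` differs from it in one place: 2-azido-1-hydroxyethyl in place of phenyl on a saturated chain carbon bound to an aromatic nitrogen. Among the measured compounds shown here, two measured steps bear on this. The move from a hydroxy-bearing chain to phenyl gave a number 98 percentage points higher from compound 1 to compound 3 (beyond the scatter), and from ethoxycarbonyl to phenyl gave a number 24 percentage points higher from compound 2 to compound 3 (beyond the scatter). Compound 4 reverses that direction, returning a hydroxy-bearing chain, so a large fall in this assay is expected, estimated as a number 70 percentage points lower from compound 3 to compound 4 (beyond the scatter). Compound 4 is therefore expected to give 40%, within a range of 10% to 85%.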

Compound 4, largest response reached (reported as maximal response), in percent of the reference or control that the assay uses: 91%
Compound 4: middle estimate off by 51 percentage points, on the low side; the measured number lies above the stated range.
By their numbers in this assay, from the lowest: compound 1; then compounds 2 and 4 (each within the scatter of the next); then compound 3.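

In this assay, the hydroxy-bearing chain alone does not bring a low response: azido in place of phenylsulfanyl gives a number 79 percentage points higher from compound 1 to compound 4 (beyond the scatter) and so ties the low value of compound 1 to the phenylsulfanyl end. The position also tolerates chains without a ring, since 2-azido-1-hydroxyethyl in place of phenyl gives only a number 19 percentage points lower from compound 3 to compound 4 (beyond the scatter) and in place of ethoxycarbonyl gives a number 5 percentage points higher from compound 2 to compound 4 (within the scatter) in this comparison. No measurement here explains the effect of phenylsulfanyl. As far as these compounds go, it remains open whether the sulfur or the phenyl ring matters, and a phenoxy or amino group in place of azido would help separate them.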